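Topoisomerase series: amine substituent swap at the fluoro-flanked position

This account rests on a few compounds, and the source may have more. Where it says the series, first, only, none or still open, it means among the compounds named here.

Measured so far:
compound 1, `O=C(O)c1cn(Cc2ccc(-c3ccccc3)cc2)c2cc(N3CC4CNCC4C3)c(F)cc2c1=O`: 33300 nM
compound 2, `O=C(O)c1cn(Cc2ccc(-c3ccccc3)cc2)c2cc(NC[C@@H]3CCNC3)c(F)cc2c1=O`: 104000 nM

Both numbers come from an assay on isolated protein for inhibition of DNA topoisomerase 1 (Homo sapiens), with a stated time of 15 min; on this read-out higher numbers stand for weaker inhibition and lower numbers for stronger inhibition. Among the measured compounds shown here, compound 2 stands at the highest of the two values, with compound 1 the nearest neighbour at the lower number; the one step known, a 3.1-fold higher number from compound 1 to compound 2 (0.49 log units; beyond the scatter), is the whole of the comparison available.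

Compound 3, `O=C(O)c1cn(Cc2ccc(-c3ccccc3)cc2)c2cc(N3C[C@H]4CCNC[C@H]4C3)c(F)cc2c1=O`, is the next entry. Relative to compound 2 the change is a group of 9 heavy atoms (7 carbon, 2 nitrogen; one five-membered non-aromatic ring with 1 hetero atom, one six-membered non-aromatic ring with 1 hetero atom) in place of a group of 7 heavy atoms (5 carbon, 2 nitrogen; one five-membered non-aromatic ring with 1 hetero atom), on an aromatic carbon. The entering group, like that of compound 1, attaches through a ring nitrogen and carries a second saturated ring, whereas compound 2 carries a single five-membered ring joined through a methylene and an amino link.

For the measured compounds named here, the only step that bears on this is a 3.1-fold higher number from compound 1 to compound 2 (0.49 log units; beyond the scatter), which shows that replacing the two-ring amine with the ((pyrrolidin-3-yl)methyl)amino group raised the number by a modest amount. Restoring a two-ring amine in compound 3 is expected to reverse roughly that amount, so a step of about a 3.0-fold lower number from compound 2 to compound 3 (0.47 log units; beyond the scatter) is expected, back towards the compound 1 level. Compound 3 is therefore estimated at 35000 nM in this assay, with a range from 12000 nM to 100000 nM.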

Compound 3, half-maximal inhibitory concentration: 61000 nM
For compound 3 the middle estimate is 1.7-fold (0.24 log units) below the measured one, and the stated range covers the measured number.
By their numbers in this assay, from the lowest: compounds 1, 3 and 2 (each within the scatter of the next, the first and the last beyond it).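

Working notes on the amine position, on an aromatic carbon ortho to a fluoro group. In this assay the entering amine, with one five-membered and one six-membered non-aromatic ring, gives a 1.7-fold lower number from compound 2 to compound 3 (0.23 log units; within the scatter) and also a 1.8-fold higher number from compound 1 to compound 3 (0.26 log units; within the scatter), so compound 3 cannot be separated from either neighbour. The earlier step therefore does not resolve into a simple contrast between two-ring amines and the ((pyrrolidin-3-yl)methyl)amino group: compound 1 and compound 2 remain apart beyond the scatter, while compound 3, which attaches through a ring nitrogen as compound 1 does, falls within the scatter of both and bridges that gap. No supporting measurement is available to account for this result.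

Still open, as far as these compounds go, is whether a piperazine or a plain dimethylamino group at this position would give a number beyond the scatter of these three, and whether the mirror-image form of the entering group of compound 3 would read any differently. Also open, from the compounds shown here alone, is whether a carboxamide in place of the carboxylic acid on the shared core would shift the whole set of amines together or change their order.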